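From compound 1 to compound 4: an aryl exchange

The compounds below may be only part of what the source reports. "The series", "measured", "known", "first", "only" and "open" are said of these compounds alone.

Measured in a physicochemical assay for lipophilicity; a lower number here means a more polar compound, a higher number a more lipophilic compound:
Compound 1 (`CN1CCN(CCCS(=O)(=O)c2ccc3nc(NC(=O)NC(=O)c4cccc(-n5cccn5)c4Cl)sc3c2)CC1`) gives 1.6
Compound 2 (`CN1CCC(S(=O)(=O)c2ccc3nc(NC(=O)NC(=O)c4cc(N5CCCC5)ccc4Cl)sc3c2)CC1`) gives 3.1
Compound 3 (`CN1CCC(S(=O)(=O)c2ccc3nc(NC(=O)NC(=O)c4cc5c(cc4Cl)CCN5C)sc3c2)CC1`) gives 2.8

Compound 1 holds the lowest of these three numbers, and compound 2 and compound 3 both lie beyond the scatter from it. Compound 4 (`CN1CCN(CCCS(=O)(=O)c2ccc3nc(NC(=O)NC(=O)c4cc(C5CC5)ccc4Cl)sc3c2)CC1`) keeps everything in compound 1 except one group, and the change is 2-chloro-5-cyclopropylphenyl in place of 2-chloro-3-(1H-pyrazol-1-yl)phenyl on a carbonyl carbon with the rest of the structure untouched.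

For the measured compounds named here, only one measured step touches the same kind of place, a carbonyl carbon: a number 0.30 log units lower from compound 2 to compound 3 (within the scatter) and it offers little guidance. It involves neither of the groups exchanged here, and compound 2 and compound 3 differ from compound 1 elsewhere too. No measurement covers this exchange directly, so the expectation rests mainly on the structural change, and a moderate rise in this assay is expected. The expected size is a number 0.60 log units higher from compound 1 to compound 4 (beyond the scatter) and it remains uncertain. For compound 4 the estimated value is 2.2 with an expected range from 1.7 to 2.8 in this assay.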

Compound 4, distribution coefficient: 2.9
Compound 4: middle estimate off by 0.70 log units, on the low side, and the stated range ends below it.
By their numbers in this assay, from the lowest: compound 1; then compounds 3, 4 and 2 (each within the scatter of the next).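

In this assay, putting 2-chloro-5-cyclopropylphenyl in place of 2-chloro-3-(1H-pyrazol-1-yl)phenyl on a carbonyl carbon gives a number 1.30 log units higher from compound 1 to compound 4 (beyond the scatter) with the rest of the structure untouched. For the compounds shown here, this shows that an exchange at this kind of place can move the number well beyond the scatter, whereas the only earlier step there, a number 0.30 log units lower from compound 2 to compound 3 (within the scatter), stayed within it. Nothing at hand explains the size of this step.

Going by these compounds alone, the two group names differ both in the ring carried and in its number on the phenyl, and the single step leaves open how much of the rise goes with each; 2-chloro-5-(1H-pyrazol-1-yl)phenyl would separate the two. Also open, on these data alone, is how an amine or a carboxylic acid in that group would read in this assay on the same structure.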